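A few compounds are considered here, and "the series" means these few. Any claim that something is new, unique, unknown or untested is made for them only; others in the source may bear on it.

Compound 1, `Nc1cc(N)c2nc(-c3ccccc3)c(Sc3ccc(F)cc3)nc2c1`: < 100000 nM
Compound 2, `CCOC(=O)[C@H](CCC(=O)O)NC(=O)c1ccc(CNc2nc3cc(N)cc(N)c3nc2-c2ccccc2)cc1`: < 100000 nM

In a functional assay on UO-31 cells (Homo sapiens) for inhibition, read by sulforhodamine B assay, with a stated time of 48 h (a higher number here means a weaker inhibitor of growth, a lower number a stronger inhibitor of growth), compound 1 gives < 100000 nM, which is a limit of the assay and not a number. Compound 2 likewise gives only a limit in this assay, < 100000 nM. For the measured compounds named here, compound 1 thus stands at the limit, as does the one further value in view: the limit of < 100000 nM in this assay, at which 2 of the 2 values shown sit. Going by the values given here, no pair of measured compounds that differ in a single place is available, so the size of any step has to be judged from the structures alone. Compound 3, `Nc1cc(N)c2nc(-c3ccccc3)c(NCc3ccc(F)cc3)nc2c1`, differs from compound 1 in one place: (4-fluorobenzyl)amino in place of (4-fluorophenyl)sulfanyl on an aromatic carbon. The expected step from compound 1 to compound 3 is a step that the limit leaves unreadable from compound 1 to compound 3, a move that is expected to stay within the usual scatter rather than beyond it, in either direction. Compound 3 is accordingly expected to give about 30000 nM in this assay, between 3000 nM and 100000 nM, with a fair chance that only a limit is again reported.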

Compound 3, concentration for total growth inhibition: < 100000 nM
Compound 3: no number, only a limit; the forecaster's own chance of this, stated with the estimate: 60%; the middle value lies beyond the limit too.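

In this assay compound 3 gives < 100000 nM, which is a limit of the assay and not a number. For the compounds shown here, compound 1 also gives only a limit, so no step between compound 1 and compound 3 can be read. The compounds shown leave open how (4-fluorobenzyl)amino in place of (4-fluorophenyl)sulfanyl affects growth inhibition, and how the compounds rank: the limit of < 100000 nM in this assay, at which 3 of the 3 values shown sit.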